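From 4-fluorophenyl to thiophen-2-yl on compound 3

The source may report more compounds than this note shows. Statements on the series, on what has been measured and on what is new or still open speak of the compounds shown alone.

In an ADME assay on cells (Hepatocyte, Mus musculus) for metabolic stability (on this read-out lower numbers stand for a shorter-lived compound and higher numbers for a longer-lived compound), compound 1 `O=c1cc(N2CCN(CC3CCC(NS(=O)(=O)c4ccccc4)CC3)CC2)sc2c([N+](=O)[O-])cc(C(F)(F)F)cc12` gives > 1.55 h, which is a limit of the assay rather than an exact number. Compound 2 `Cc1ccc(C(=O)OC2CCC(CN3CCN(c4cc(=O)c5cc(C(F)(F)F)cc([N+](=O)[O-])c5s4)CC3)CC2)cc1` gives 0.202 h. Compound 3 `O=C(OC1CCC(CN2CCN(c3cc(=O)c4cc(C(F)(F)F)cc([N+](=O)[O-])c4s3)CC2)CC1)c1ccc(F)cc1` gives 0.0817 h, the lower of the two exact numbers. Compound 4 `O=C(OC1CCC(CN2CCN(c3cc(=O)c4cc(C(F)(F)F)cc([N+](=O)[O-])c4s3)CC2)CC1)c1cccs1` has not yet been measured. It carries thiophen-2-yl in place of 4-fluorophenyl on a carbonyl carbon.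

The closest guide is a change on the same aromatic group, fluoro in place of methyl, which gave a modest step: a 2.5-fold lower number from compound 2 to compound 3 (0.39 log units; beyond the scatter). Two larger steps, an at least 7.6-fold lower number from compound 1 to compound 2 (0.88 log units; beyond the scatter) and an at least 18-fold lower number from compound 1 to compound 3 (1.27 log units; beyond the scatter), replace (phenylsulfonyl)amino on a saturated ring carbon, a change that does not occur here, so they offer little guidance. Only a small shift is therefore expected, with a slight rise as the best guess. The estimated step is a 1.3-fold higher number from compound 3 to compound 4 (0.13 log units; within the scatter). For compound 4 the estimated half-life is 0.11 h, with an expected range from 0.04 h to 0.3 h.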

Compound 4, half-life: 0.0867 h
Beside the measured number, compound 4's estimate is 1.3-fold (0.10 log units) above it; measured number inside the range.
By their numbers in this assay, from the lowest: compounds 3 and 4 (each within the scatter of the next); then compound 2. At a limit, above all of these: compound 1.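

In this assay, thiophen-2-yl on this carbonyl carbon cannot be told apart from 4-fluorophenyl, a 1.1-fold higher number from compound 3 to compound 4 (0.03 log units; within the scatter), yet it differs from 4-methylphenyl, a 2.3-fold lower number from compound 2 to compound 4 (0.37 log units; beyond the scatter), so among these three rings only 4-methylphenyl stands apart. The change at the saturated ring carbon remains far larger than any change on the carbonyl carbon: an at least 17-fold lower number from compound 1 to compound 4 (1.25 log units; beyond the scatter). The value of compound 1 is a limit and not an exact number: the limit of > 1.55 h in this assay, at which 1 of the 4 values shown sits.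

The compounds shown leave open how a ring carrying an amine or a carboxylic acid would read on this carbonyl carbon, or how a pyridine ring would. They also leave open whether a ((thiophen-2-yl)carbonyl)amino group on the saturated ring carbon would read closer to compound 1 or to compound 4.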